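The compounds below may be only part of what the source reports. "The series", "measured", "known", "first", "only" and "open" are said of these compounds alone.

Measured in a functional assay on HL-60 cells (Homo sapiens) for cytotoxicity, read by WST assay, with a stated time of 48 h; on this read-out higher numbers stand for weaker inhibition and lower numbers for stronger inhibition:
- compound 1 `COc1cc(C(c2ccc(O)c(OC)c2)[C@@H](C)[C@@H](C)CO)ccc1O` gives > 100000 nM as a limit of the assay
- compound 2 `COc1cc(C(c2ccc(O)c(OC)c2)[C@H](C)C(C)C)ccc1O` gives 17000 nM as a number
- compound 3 `COc1cc(C(c2ccc(O)c(OC)c2)[C@H](CC(C)C)C(C)C)ccc1O` gives 9600 nM as a number

Compound 3 sits with compound 2 at the low end of the series, with a 1.8-fold lower number from compound 2 to compound 3 (0.25 log units; within the scatter) between them. The next case is compound 4 `COc1cc(C(c2ccc(O)c(OC)c2)[C@H](C)[C@@H](C)CO)ccc1O`, not yet measured. The change is 2-(hydroxymethyl)-1-methylpropyl in place of 1-isopropyl-3-methylbutyl on a saturated chain carbon bound to two aromatic carbons, with 2-(hydroxymethyl)-1-methylpropyl in place of 1-isopropyl-3-methylbutyl on a saturated chain carbon bound to two aromatic carbons.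

Compound 1 carries the entering group by name, so the closest guide is an at least 10-fold lower number from compound 1 to compound 3 (1.01 log units; beyond the scatter), read in reverse. The step of an at least 5.8-fold lower number from compound 1 to compound 2 (0.76 log units; beyond the scatter), also read in reverse, points the same way and is somewhat smaller. Going by these compounds, compound 1 stands at the limit of > 100000 nM in this assay, at which 1 of the 3 values shown sits, and that value is only a limit, so the true size of both steps stays open.

A large move toward weaker inhibition in this assay is therefore expected. The estimated step is a 7.3-fold higher number from compound 3 to compound 4 (0.86 log units; beyond the scatter) and it may end in a limit. Compound 4 is estimated at 70000 nM with an expected range from 25000 nM to 200000 nM in this read-out.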

Compound 4, half-maximal inhibitory concentration: > 100000 nM
Compound 4 ended at the assay's limit; the forecaster's own chance of this, stated with the estimate: 50%; middle value at least 1.4-fold (0.15 log units) away from the limit.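

In this assay, the hydroxy-bearing side chain reaches the top of the range in a second configuration, so the loss is not confined to one drawn form of this stereocentre: the fact that compounds 1 and 4 differ only in the configuration as drawn Hydroxy in place of hydrogen gives an at least 5.8-fold higher number from compound 2 to compound 4 (0.76 log units; beyond the scatter), and the full exchange of 1-isopropyl-3-methylbutyl for 2-(hydroxymethyl)-1-methylpropyl gives an at least 10-fold higher number from compound 3 to compound 4 (1.01 log units; beyond the scatter). Compound 4 gives > 100000 nM, which is a limit of the assay, and compound 1 also stands at a limit, so the step linking them cannot be read: the limit of > 100000 nM in this assay, at which 2 of the 4 values shown sit.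

Going by these compounds, the real gap between the two configurations stays open, as does the true size of both steps to compound 4. Also open, on these data alone, is whether an amine, a carboxylic acid or a methyl ether in place of the hydroxy, or a longer chain carrying it, would give the same result.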